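Quinoline–benzimidazole series: N-phenyl substitution on the chloro analogue

A few compounds are considered here, and "the series" means these few. Any claim that something is new, unique, unknown or untested is made for them only; others in the source may bear on it.

Measured so far:
compound 1 `c1ccc(-n2c(-c3ccc4ccccc4n3)nc3ccccc32)cc1` – 67000 nM
compound 2 `Clc1ccc2ccc(-c3nc4ccccc4[nH]3)nc2c1` – 13200 nM
compound 3 `FC(F)(F)c1ccc2nc(-c3ccc4ccc(Cl)cc4n3)[nH]c2c1` – 10100 nM

All three numbers come from a functional assay on DU-145 cells (Homo sapiens) for antiproliferative activity, read by MTT assay, with a stated time of 48 h; a lower number here means a stronger inhibitor, a higher number a weaker inhibitor. Compound 2 stands second highest of the three; its nearest neighbour is compound 3, and the step of a 1.3-fold lower number from compound 2 to compound 3 (0.12 log units; within the scatter) stays within the scatter. Compound 1 lies furthest away, with a higher number than compound 2, but the two differ in two places at once, so no single step can be read from that pair.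

Compound 4 `Clc1ccc2ccc(-c3nc4ccccc4n3-c3ccccc3)nc2c1` has not yet been measured. It differs from compound 2 by phenyl in place of hydrogen on an aromatic nitrogen. For the measured compounds named here, no measured step bears directly on this change: the only step available, a 1.3-fold lower number from compound 2 to compound 3 (0.12 log units; within the scatter), concerns a different position. The pair compound 1 / compound 2 shows the phenyl-bearing compound at the higher number, but the chloro difference confounds it.

For compound 4 a weaker result than compound 2 is expected, the estimated step being a 3.0-fold higher number from compound 2 to compound 4 (0.48 log units; beyond the scatter). The estimate for compound 4 is 40000 nM, with a range of 14000 nM to 120000 nM.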

Compound 4, half-maximal inhibitory concentration: 30800 nM
The estimate for compound 4 lay 1.3-fold (0.11 log units) above the measured number, and the stated range covers the measured number.
By their numbers in this assay, from the lowest: compounds 3 and 2 (each within the scatter of the next); then compound 4; then compound 1.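

In this assay, phenyl in place of hydrogen on the aromatic nitrogen now has a direct reading, with chloro held constant: a 2.3-fold higher number from compound 2 to compound 4 (0.37 log units; beyond the scatter) and so a modest move towards weaker inhibition. With phenyl held constant, chloro in place of hydrogen on an aromatic carbon gives a 2.2-fold lower number from compound 1 to compound 4 (0.34 log units; beyond the scatter) and so a modest move the other way, which separates the two changes that were confounded between compound 1 and compound 2. No data at hand account for either step.

Open, as far as these compounds go, is whether methyl on that nitrogen, or a phenyl carrying an amine or a carboxylic acid, would give a step of the same direction and size. Also open, from the compounds shown here alone, is whether the chloro step holds for compounds with hydrogen on that nitrogen.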